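Swapping the alkenyl chain for benzyl on the ring nitrogen

This account rests on a few compounds, and the source may have more. Where it says the series, first, only, none or still open, it means among the compounds named here.

Compound 1, `C=CCN1CCCC(/C=C/c2ccccc2)C1`, in an assay on isolated protein for binding affinity to Sigma non-opioid intracellular receptor 1 (Rattus norvegicus); on this read-out lower numbers stand for stronger inhibition and higher numbers for weaker inhibition: 4 nM
Compound 2, `CC(C)=CCN1CCCC(/C=C/c2ccccc2)C1`, in this assay : 38 nM
Compound 3, `C=CCCCN1CCCC(/C=C/c2ccccc2)C1`, in this assay : 12 nM

Compound 3 holds the second highest of the three numbers. Its nearest neighbour is reached by a 3.0-fold higher number from compound 1 to compound 3 (0.48 log units; beyond the scatter), its furthest by a 3.2-fold lower number from compound 2 to compound 3 (0.50 log units; beyond the scatter).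

Compound 4 is `C(=C/C1CCCN(Cc2ccccc2)C1)\c1ccccc1`. It differs from compound 3 by phenyl in place of but-3-en-1-yl on a saturated chain carbon bound to an amine nitrogen in a ring. All three measured steps change the group on that same carbon, but none of them brings in an aromatic ring, so they bear on this step only indirectly. a 3.0-fold higher number from compound 1 to compound 3 (0.48 log units; beyond the scatter) shows a modest cost for a longer chain, and a 9.5-fold higher number from compound 1 to compound 2 (0.98 log units; beyond the scatter) a larger one for a branched chain. Going by the values given here, a benzyl group is bulkier than any of these, yet the measured series gives no direct precedent for an aromatic ring here. A modest step in either direction is therefore expected, with a 1.2-fold lower number from compound 3 to compound 4 (0.08 log units; within the scatter) as the central guess. Compound 4 is estimated at 10 nM, in a range from 2 nM to 50 nM.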

Compound 4, half-maximal inhibitory concentration: 10 nM
For compound 4 middle estimate and measured number coincide at the digits printed; the measured number falls inside the stated range.
By their numbers in this assay, from the lowest: compound 1; then compounds 4 and 3 (each within the scatter of the next); then compound 2.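

On the saturated chain carbon bound to an amine nitrogen in a ring, this assay shows that an aromatic ring can take the place of an alkenyl group: phenyl in place of but-3-en-1-yl gives a 1.2-fold lower number from compound 3 to compound 4 (0.08 log units; within the scatter). The same change gives a 3.8-fold lower number from compound 2 to compound 4 (0.58 log units; beyond the scatter) against 2-methylprop-1-en-1-yl, but a 2.5-fold higher number from compound 1 to compound 4 (0.40 log units; beyond the scatter) against vinyl, so benzyl on the ring nitrogen matches pent-4-en-1-yl without reaching the short allyl chain of compound 1. No accompanying evidence bears on these differences.

The compounds shown leave open whether a phenethyl group, with a longer chain leading to the phenyl, would behave like benzyl. They also leave open what a fluorine or a methoxy group on the phenyl of compound 4 would do.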